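A few compounds are considered here, and "the series" means these few. Any claim that something is new, unique, unknown or untested is made for them only; others in the source may bear on it.

Working notes on the sulfonamide series.

Compound 1, `CC(C)(C)c1ccc(CNCCCNS(=O)(=O)c2cc(C(F)(F)F)cc(C(F)(F)F)c2)cc1`, is measured in a functional assay on U-87MG ATCC cells for inhibition, with U-87 MG (Homo sapiens) as the target, read by MTT assay, with a stated time of 72 h (a lower number here means a stronger inhibitor of growth, a higher number a weaker inhibitor of growth), and gives 2300 nM. Compound 2, `O=S(=O)(NCCNCc1ccc(-c2ccccc2)cc1)c1cc(C(F)(F)F)cc(C(F)(F)F)c1`, gives 1400 nM in this assay. Among the measured compounds shown here, of the two numbers so far, compound 1 carries the higher one; the gap to compound 2 is within the scatter, so no order between them can be read from these two values.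

Compound 3, `COc1ccc(CNCCCNS(=O)(=O)c2cc(C(F)(F)F)cc(C(F)(F)F)c2)cc1OC`, is not yet measured. It differs from compound 1 at one place: 3,4-dimethoxyphenyl in place of 4-(tert-butyl)phenyl on a saturated chain carbon bound to an amine nitrogen

For the measured compounds named here, no pair of measured compounds shows this kind of change, so there is no measured step to lean on. With only compound 1 and compound 2 to go by, and neither giving a strong inhibitor of growth, the step is expected to be modest and, if anything, toward a higher number, with a shift no larger than the scatter itself equally plausible. For compound 3 the estimate is 3000 nM, with a range from 1200 nM to 8000 nM. This estimate corresponds to a step of a 1.3-fold higher number from compound 1 to compound 3 (0.12 log units; within the scatter).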

Compound 3, concentration for 50% growth inhibition: 3400 nM
Compound 3: the middle estimate sits 1.1-fold (0.05 log units) below what was measured; measured number inside the range.
By their numbers in this assay, from the lowest: compounds 2, 1 and 3 (each within the scatter of the next, the first and the last beyond it).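

Replacing 4-(tert-butyl)phenyl with 3,4-dimethoxyphenyl on a saturated chain carbon bound to an amine nitrogen now gives a measured step at this position: in this assay it is a 1.5-fold higher number from compound 1 to compound 3 (0.17 log units; within the scatter) and lies within the scatter. This position therefore takes an aromatic ring with 2 hydrogen-bond acceptors in place of one with 0, at an equal heavy-atom count, without a step beyond the scatter, and no order can be read between these two compounds. Nothing measured here offers an explanation for this result.

From the compounds shown here alone, whether any other group at this position gives a step beyond the scatter remains open. A benzyl carrying a carboxylic acid or a primary amine, or a longer chain between the two nitrogens, would test this.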